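From furan-3-yl to pyridin-2-yl on the shared core

This account rests on a few compounds, and the source may have more. Where it says the series, first, only, none or still open, it means among the compounds named here.

In an ADME assay on BHK-21 cells (Mesocricetus auratus) for cytotoxicity, read by MTT assay (a lower number here means that less compound is tolerated, a higher number that more compound is tolerated), compound 3 `C/C(=N\NC(N)=O)c1ccc2c(c1)nc(-c1ccoc1)n2C1CCCCC1` stands at "not determined" (no result reported) and so offers no number to start from. Two related compounds give some context. Compound 1 `C/C(=N\NC(N)=O)c1ccc2c(c1)nc(-c1ccc(Cl)cc1)n2C1CCCCC1` shows > 100000 nM as a limit of the assay and not a number. Compound 2 `COc1ccc(-c2nc3cc(/C(C)=N/NC(N)=O)ccc3n2C2CCCCC2)c(OC)c1` gives 19000 nM as a true number. Compound 4 `C/C(=N\NC(N)=O)c1ccc2c(c1)nc(-c1ccccn1)n2C1CCCCC1` differs from compound 3 by one group: pyridin-2-yl in place of furan-3-yl on an aromatic carbon with pyridin-2-yl in place of furan-3-yl on an aromatic carbon, next to the ring atom that bears a cyclohexyl group. For the measured compounds named here, the one measured step at this place, with 2,4-dimethoxyphenyl in place of 4-chlorophenyl, is an at least 5.2-fold lower number from compound 1 to compound 2 (0.72 log units; beyond the scatter) and it lies beyond the scatter. Neither of those groups appears in the new change, and with no number for compound 3, no size or direction of step can be expected. Going by the values given here, the span of that measured step is the only guide left. Compound 4 is estimated at 60000 nM with an expected range from 17000 nM to 150000 nM for its measured value.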

Compound 4, half-maximal cytotoxic concentration: > 100000 nM
Compound 4 gave a limit, no number; the forecaster's own chance of this, stated with the estimate: 45%; middle value at least 1.6-fold (0.22 log units) from the limit.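

In this assay compound 4 stands at > 100000 nM, a limit of the assay and not a number. Putting pyridin-2-yl in place of 2,4-dimethoxyphenyl on this aromatic carbon gives an at least 5.2-fold higher number from compound 2 to compound 4 (0.72 log units; beyond the scatter), so a second aromatic group besides 4-chlorophenyl now reaches the top of the range, and among the compounds with a reading, compound 2 is the one that goes against this. The step between compound 1 and compound 4 cannot be read, and the result leaves these two compounds sharing one ceiling: the limit of > 100000 nM in this assay, at which 2 of the 4 values shown sit.

Where furan-3-yl stands on this scale stays open, as does how far compound 1 and compound 4 would separate beyond the limit. As far as these compounds go, how an amine or a carboxylic acid at this position would read also remains unknown.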